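Shortening the sulfur substituent on a triazole thioether series

The source may hold more compounds than are shown below. What is called first, only, known or untested is meant among the compounds shown, and "the series" means these compounds.

Measured compounds:
Compound 1 `O=C(CCl)Nn1c(COc2ccccc2C2=NOC(c3ccc(Cl)cc3Cl)C2)nnc1Sc1ccccc1` gives "not determined" (no result reported) in an ADME assay (MDM cells, Homo sapiens) for cytotoxicity, read by resazurin assay, with a stated time of 3 days; on this read-out lower numbers stand for stronger inhibition and higher numbers for weaker inhibition.
Compound 2 `CCOC(=O)CC(=O)CSc1nnc(COc2ccccc2C2=NOC(c3ccc(Cl)cc3Cl)C2)n1NC(C)=O` gives "not determined" (no result reported) in this assay.
Compound 3 `CCCSc1nnc(COc2ccccc2C2=NOC(c3ccc(Cl)cc3Cl)C2)n1NC(=O)CCl` gives 28.7 ug/mL in this assay.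

Compound 2 stands without a number in this assay: no result was reported for it, and the same holds for compound 1, so only compound 3 provides a measured value in this series. Compound 3 sits at 28.7 ug/mL in this assay, and this single point is the only anchor for any expectation.

Compound 4 `CC(=O)Nn1c(S)nnc1COc1ccccc1C1=NOC(c2ccc(Cl)cc2Cl)C1` is the thiol that results from compound 2 through the change (hydrogen in place of (((ethoxycarbonyl)methyl)carbonyl)methyl on a sulfur). The shared core and the acetylamino group on the ring nitrogen are kept.

No measured step exists between any two of these compounds, so the size of the change from compound 2 to compound 4 in this assay cannot be read from data. Given that compound 3, which carries a propyl group on the same sulfur, shows 28.7 ug/mL in this assay, a compound of this core with a small sulfur substituent is taken as the nearest reference, and no step beyond the scatter is expected in either direction relative to that reference.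

On that basis compound 4 is estimated at 30 ug/mL in this assay, with an expected range from 10 ug/mL to 90 ug/mL.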

Compound 4, half-maximal inhibitory concentration: 1.3 ug/mL
Compound 4: middle estimate off by 23-fold (1.36 log units), on the high side, outside the stated range (below it).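

Going by these compounds alone, compound 4 gives 1.3 ug/mL in this assay and compound 2 holds no single number there, so no step between compound 2 and compound 4 can be read. The compounds shown leave open how the group on the sulfur alone bears on this read-out. No supporting evidence bears on the value of compound 4.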